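Para-fluoro on the phenoxy ring of a hydroxamate-derived benzamide

The source may report more compounds than this note shows. Statements on the series, on what has been measured and on what is new or still open speak of the compounds shown alone.

The series rests on a shared core, first seen in compound 1 `O=C(NO)c1ccc(COc2ccccc2)cc1`, for which a functional assay on MGC-803 cells (Homo sapiens) for antiproliferative activity, read by CCK-8 assay, with a stated time of 72 h (on this read-out higher numbers stand for weaker inhibition and lower numbers for stronger inhibition), reports "not determined" (no result reported). Going by the values given here, compound 2 `Nc1ccccc1NC(=O)c1ccc(COc2ccccc2)cc1` carries the only number yet available, giving 5670 nM in this assay, so it stands alone as the sole reference point. Compound 3 `Nc1ccccc1NC(=O)c1ccc(COc2ccc(F)cc2)cc1` differs from compound 2 by fluoro in place of hydrogen on an aromatic carbon. Among the compounds with values here, with no step between measured compounds to lean on, the change is expected to move this assay by no more than the usual scatter, a step of a 1.3-fold lower number from compound 2 to compound 3 (0.10 log units; within the scatter). Compound 3 is therefore estimated at 4500 nM, within 1500 nM to 13000 nM.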

Compound 3, half-maximal inhibitory concentration: 4970 nM
Beside the measured number, compound 3's estimate is 1.1-fold (0.04 log units) below it; low and high end bracket the measured number.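

Fluoro in place of hydrogen on an aromatic carbon, para to a large group, gives the first readable step in this assay, a 1.1-fold lower number from compound 2 to compound 3 (0.06 log units; within the scatter). This position therefore accepts a single fluorine atom with no change that can be told from the scatter. Nothing at hand explains this result. From the compounds shown here alone, whether chloro, methoxy or an amine at the same place would move the number beyond the scatter remains open. So does the effect of fluoro elsewhere on this ring, or on the ring carrying the amine.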